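Shifting a Methoxy Group: From Compound 1 to Compound 4

A few compounds are considered here, and "the series" means these few. Any claim that something is new, unique, unknown or untested is made for them only; others in the source may bear on it.

Compound 1 `COc1ccccc1COc1ccccc1/C=C/C=C1\SC(=S)NC1=O` carries a 2-methoxyphenyl group. In a functional assay on DLD-1 cells (Homo sapiens), read by microscopy and crystal violet staining, with a stated time of 20 h, tested at 10 ug/mL (a lower number here means less inhibition, a higher number more inhibition at the concentration tested (going by the name of the read-out)), compound 1 gives 98%, the highest of the three measured numbers. Compound 2 `O=C1NC(=S)S/C1=C\C=C\c1ccccc1` gives 81% and compound 3 `O=C1NC(=S)S/C1=C\C=C\c1ccccc1Cl` gives 80%; the step of a number 1 percentage points lower from compound 2 to compound 3 (within the scatter) shows that chloro in place of hydrogen on an aromatic carbon stays within the usual scatter. Compound 4 `COc1cccc(COc2ccccc2/C=C/C=C2\SC(=S)NC2=O)c1` differs from compound 1 by 3-methoxyphenyl in place of 2-methoxyphenyl on a saturated chain carbon bound to an oxygen on an aromatic ring. Among the measured compounds shown here, no measured step mirrors this change, and the only measured step was within the scatter, so no step beyond the scatter is expected here. Because compound 1 gives 98% near the top of the scale, the expected step is a number 5 percentage points lower from compound 1 to compound 4 (within the scatter). For compound 4 the estimate is 93%, between 78% and 100%.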

Compound 4, a percentage reported as inhibition, at one concentration (the size of the read-out at that concentration, not a potency): 82%
For compound 4 the middle estimate is 11 percentage points above the measured one; the measured number falls inside the stated range.
By their numbers in this assay, from the lowest: compounds 3, 2 and 4 (each within the scatter of the next); then compound 1.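

Putting 3-methoxyphenyl in place of 2-methoxyphenyl gives a number 16 percentage points lower from compound 1 to compound 4 (beyond the scatter) in this assay. Among the compounds shown here, the two compounds have the same atoms, joined differently, so rearranging this group alone, on a saturated chain carbon bound to an oxygen on an aromatic ring, moves the number beyond the scatter, whereas the only earlier step stayed within it. Nothing at hand gives a reason for this step. The compounds shown leave open whether an ethoxy group, a hydroxyl or an amine in place of the methoxy group would keep the number high.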